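The compounds below may be only part of what the source reports. "The series", "measured", "known", "first", "only" and "open" are said of these compounds alone.

The measured compounds:
Compound 1, `Nc1ncnc2c1nc(NCc1ccccc1-c1ccccc1)n2[C@@H]1O[C@H](CO)[C@@H](O)[C@H]1O`, in an assay on COS-7 cells for inhibition of sodium/nucleoside cotransporter 2 (Homo sapiens), read by scintillation counting, in the presence of a further agent that is not named here (on this read-out lower numbers stand for stronger inhibition and higher numbers for weaker inhibition), gives > 100000 nM, a limit of the assay and not a number.
Compound 2, `Nc1ncnc2c1nc(NCc1ccc(-c3ccccc3)cc1)n2[C@@H]1O[C@H](CO)[C@@H](O)[C@H]1O`, gives 640 nM.
Compound 3, `CCCCCOC(=O)OC[C@H]1O[C@@H](n2cnc3c(N)ncnc32)[C@H](O)[C@@H]1O`, gives > 100000 nM, again a limit.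

Compound 1 therefore stands at the limit of > 100000 nM in this assay, at which 2 of the 3 values shown sit, with no number of its own to compare. Compound 4, `Cc1ccccc1CNc1nc2c(N)ncnc2n1[C@@H]1O[C@H](CO)[C@@H](O)[C@H]1O`, keeps the core of compound 1 and carries methyl in place of phenyl on an aromatic carbon. No measured pair isolates such a change, so the size of the step from compound 1 to compound 4 cannot be read from the data shown. Compound 4 is expected at 30000 nM, within 3000 nM to 100000 nM. The expected step of an at least 3.3-fold lower number from compound 1 to compound 4 (0.52 log units; beyond the scatter) appears large only because compound 1 sits at the limit of > 100000 nM in this assay, at which 2 of the 3 values shown sit, and a fair chance remains that compound 4 also returns only a limit.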

Compound 4, half-maximal inhibitory concentration: 65000 nM
Estimate against measurement, compound 4: 2.2-fold (0.34 log units) below, and the stated range covers the measured number.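

With the methyl group on this aromatic carbon, ortho to a large group, compound 4 returns a measured number in this assay, where the phenyl of compound 1 returned only a limit. The change gives an at least 1.5-fold lower number from compound 1 to compound 4 (0.18 log units; that floor lies within the scatter), so it can be read only as a floor. The true size of the step stays unknown because compound 1 is held at a limit: the limit of > 100000 nM in this assay, at which 2 of the 4 values shown sit.

As far as these compounds go, whether an ethyl group, a methoxy group or an amine on this aromatic carbon would move the read-out further stays open. So does whether a bare hydrogen there would serve as well as the methyl group.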